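One change at the carbonyl: tert-butoxy to (tert-butyl)amino

This account rests on a few compounds, and the source may have more. Where it says the series, first, only, none or still open, it means among the compounds named here.

Compound 1, `CCN(CC)S(=O)(=O)c1ccc(S(=O)(=O)N2CCC[C@@H](C(=O)NC3CN(C(=O)OC(C)(C)C)C3)C2)cc1`, gives 1800 nM in a functional assay on BXPC-3 cells (Homo sapiens) for inhibition, read by MTT assay, with a stated time of 7 days; a higher number here means a weaker inhibitor, a lower number a stronger inhibitor.
Compound 2, `CCOC(=O)[C@@H]1CCC[C@H](S(=O)(=O)c2ccc(S(=O)(=O)N(CC)CC)cc2)C1`, gives 25200 nM in this assay.

Of these two numbers, compound 1 holds the lower one, and the gap up to compound 2 lies well beyond the usual scatter; the two structures differ in more than one place, so the pair teaches nothing about a single change. Compound 3, `CCN(CC)S(=O)(=O)c1ccc(S(=O)(=O)N2CCC[C@@H](C(=O)NC3CN(C(=O)NC(C)(C)C)C3)C2)cc1`, is the next case. It differs from compound 1 in one place only: (tert-butyl)amino in place of tert-butoxy on a carbonyl carbon. Going by the values given here, no measured pair shows this particular change, so the expectation rests on the value of compound 1 alone. The step from compound 1 to compound 3 is expected to be a 1.1-fold lower number from compound 1 to compound 3 (0.05 log units; within the scatter), which is to say no shift beyond the scatter, in either direction. Compound 3 is therefore estimated at 1600 nM, with a range from 500 nM to 5000 nM.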

Compound 3, half-maximal inhibitory concentration: 10100 nM
Compound 3: the middle estimate sits 6.3-fold (0.80 log units) below what was measured; the whole stated range lies below it.
By their numbers in this assay, from the lowest: compound 1; then compound 3; then compound 2.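

Replacing tert-butoxy with (tert-butyl)amino on a carbonyl carbon gives a 5.6-fold higher number from compound 1 to compound 3 (0.75 log units; beyond the scatter) in this assay, even though both groups have the same heavy-atom count and differ mainly in one atom, oxygen or nitrogen, and in carrying a hydrogen-bond acceptor or a hydrogen-bond donor. This position is therefore sensitive to a small edit, at least in this single pair, and tert-butoxy is the better of the two groups here. Nothing available here shows which part of the swap accounts for the step.

On these data alone, it remains open whether a smaller group on the same carbonyl carbon, such as methoxy or methyl, would keep the number of compound 1 or lose ground as well. It is also unsettled how (tert-butyl)(methyl)amino, which keeps the nitrogen but has no hydrogen on it, would compare with these two groups.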